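Trifluoromethyl on the benzoyl ring of compound 3

The compounds below may be only part of what the source reports. "The series", "measured", "known", "first", "only" and "open" are said of these compounds alone.

Three compounds share one core, and they differ in the group on the benzoyl ring and in the group on the pyrazole nitrogen. Compound 1 `CCOC(=O)c1nc(NC(=O)c2ccc(F)cc2)nc2nn(C)cc12` gives, in an assay on CHO cells for displacement of a labelled ligand from adenosine receptor A3 (Homo sapiens) (a lower number here means a stronger inhibitor, a higher number a weaker inhibitor), only a limit of the assay, > 100000 nM. Compound 2 `CCOC(=O)c1nc(NC(=O)c2ccc(C)cc2)nc2nn(C)cc12` gives 100000 nM. Compound 3 `CCOC(=O)c1nc(NC(=O)c2ccccc2)nc2nn(C(C)C)cc12` gives 8600 nM, the lowest of the two numbers; the nearest is compound 2, with a higher number, a gap beyond the scatter. Among the compounds with values here, the single measured step, from compound 1 to compound 2, reads a number no higher from compound 1 to compound 2 (the limit leaves the size open), and its size cannot be read because compound 1 sits at the limit of > 100000 nM in this assay, at which 1 of the 3 values shown sits.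

Compound 4 `CCOC(=O)c1nc(NC(=O)c2ccc(C(F)(F)F)cc2)nc2nn(C(C)C)cc12` differs from compound 3 by trifluoromethyl in place of hydrogen on an aromatic carbon. Within the data shown here, no measured step places a group on an otherwise bare benzoyl ring, so the size of this change has no direct precedent. Among the measured compounds shown here, compounds 1 and 2 differ from compound 3 in two places and give no isolated step. The expectation is a step of a 1.7-fold higher number from compound 3 to compound 4 (0.24 log units; within the scatter), with compound 4 estimated at 15000 nM, between 3000 nM and 100000 nM in this assay.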

Compound 4, inhibition constant: > 100000 nM
Compound 4: a limit, no number; the forecaster's own chance of this, stated with the estimate: 20%; middle value at least 6.6-fold (0.82 log units) from the limit.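

Trifluoromethyl on an aromatic carbon para to a large group is the first single change shown on the bare benzoyl ring of compound 3, and in this assay it gives an at least 11-fold higher number from compound 3 to compound 4 (1.06 log units; beyond the scatter). This pair shows that the ring position is not indifferent to what it carries: with the isopropyl group on the pyrazole nitrogen, the bare ring gives a measured number and the substituted ring does not. Compound 4 stands at a limit of the assay rather than at a number, and the full size of the step cannot be read because of that limit: the limit of > 100000 nM in this assay, at which 2 of the 4 values shown sit.

Going by these compounds, whether chloro, methoxy or an amine at this same place would also weaken binding stays open. So does whether fluoro or methyl would do so with the isopropyl group kept.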